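This account rests on a few compounds, and the source may have more. Where it says the series, first, only, none or still open, it means among the compounds named here.

Compound 1 `CC(C)(C)c1ccc(C(=O)NCc2ccc(C(N)=O)cc2)cc1` gives 3800 nM in an assay on HeLa cells with Bile acid receptor (Homo sapiens) as the target, read by a luciferase reporter, with a stated time of 24 h (a lower number here means that less compound is needed, a higher number that more compound is needed for the effect), the highest of the three numbers seen so far. Compound 2 `CC(C)(C)c1ccc(C(=O)NCc2ccc(-c3nnn[nH]3)cc2)cc1` gives 120 nM in this assay, and compound 3 `CSc1ccc(CNC(=O)c2ccc(C(C)(C)C)cc2)cc1` gives 100 nM. Both measured steps away from compound 1 alter the same group and are large: a 32-fold lower number from compound 1 to compound 2 (1.50 log units; beyond the scatter) and a 38-fold lower number from compound 1 to compound 3 (1.58 log units; beyond the scatter). Compound 4 `CC(=O)Nc1ccc(CNC(=O)c2ccc(C(C)(C)C)cc2)cc1` varies that group once more: acetamido in place of carbamoyl on an aromatic carbon. Unlike the two measured replacements, the acetamido keeps 1 hydrogen-bond donor and 1 hydrogen-bond acceptor, as the carbamoyl had. A drop smaller than either measured one is therefore expected, a 3.8-fold lower number from compound 1 to compound 4 (0.58 log units; beyond the scatter), because a 32-fold lower number from compound 1 to compound 2 (1.50 log units; beyond the scatter) and a 38-fold lower number from compound 1 to compound 3 (1.58 log units; beyond the scatter) both followed loss of the carbamoyl. Compound 4 is estimated at 1000 nM, within 300 nM to 4000 nM.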

Compound 4, half-maximal effective concentration: 2900 nM
Beside the measured number, compound 4's estimate is 2.9-fold (0.46 log units) below it; the measured number falls inside the stated range.
By their numbers in this assay, from the lowest: compounds 3 and 2 (each within the scatter of the next); then compounds 4 and 1 (each within the scatter of the next).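

At this position, para to a large group, acetamido and carbamoyl cannot be told apart in this assay, with a 1.3-fold lower number from compound 1 to compound 4 (0.12 log units; within the scatter) as the step. The large steps are not shared by every replacement of the carbamoyl: a 29-fold higher number from compound 3 to compound 4 (1.46 log units; beyond the scatter) and a 24-fold higher number from compound 2 to compound 4 (1.38 log units; beyond the scatter) place the acetamido with the carbamoyl, apart from methylsulfanyl and 1H-tetrazol-5-yl. No measurement accounts for this split. Open, from the compounds shown here alone, is where a carboxylic acid or an amine at this position would fall relative to these two pairs, and whether a longer chain on the acetamido carbonyl would leave the number within the scatter of compound 4.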